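A few compounds are considered here, and "the series" means these few. Any claim that something is new, unique, unknown or untested is made for them only; others in the source may bear on it.

Compound 2 `CC(C)COc1cccc2occ(Cc3coc4ccccc4c3=O)c(=O)c12` is reported in a functional assay on HCT-15 cells (Homo sapiens) for antiproliferative activity, read by XTT assay (on this read-out lower numbers stand for stronger inhibition and higher numbers for weaker inhibition), only as a limit: compound 2 gives > 10000 nM in this assay. Compound 1 `O=c1c(Cc2coc3cccc(OCC4CCCCC4)c3c2=O)coc2cc(Cl)ccc12` gives > 10000 nM in this assay, again a limit. Compound 3 `O=c1c(CCc2coc3ccccc3c2=O)coc2ccccc12` gives > 10000 nM in this assay, also a limit. Going by the values given here, all three values share (the limit of > 10000 nM in this assay, at which 3 of the 3 values shown sit), so no measured step in this assay separates any pair of them. Compound 4 `COc1cccc2occ(Cc3coc4ccccc4c3=O)c(=O)c12` differs from compound 2 by hydrogen in place of isopropyl on a saturated chain carbon bound to an oxygen on an aromatic ring, the isobutyl to methyl cut. With every value of the series sitting at the limit, no step beyond the scatter is expected, and the change from compound 2 to compound 4 is estimated at a step that the limit leaves unreadable from compound 2 to compound 4. The estimate for compound 4 is 20000 nM, with a range from 4000 nM to 100000 nM.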

Compound 4, half-maximal inhibitory concentration: 3430 nM
The estimate for compound 4 lay 5.8-fold (0.77 log units) above the measured number, outside the stated range (below it).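

In this assay, the isobutyl to methyl cut gives an at least 2.9-fold lower number from compound 2 to compound 4 (0.46 log units; beyond the scatter), the first measured separation in the series. The group on this oxygen therefore matters to the read-out, and the smaller methoxy is the one that comes off the limit. Compound 2 stands only as a limit, > 10000 nM, so the full size of the step stays unread.

As far as these compounds go, only isobutoxy and methoxy can be compared here, so any trend with chain size remains open. An ethoxy group or a free hydroxyl at this place would test it.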